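The source may report more compounds than this note shows. Statements on the series, on what has been measured and on what is new or still open speak of the compounds shown alone.

Compound 1 `Cc1cccc(-n2cc(-c3ccccc3NS(=O)(=O)c3c[nH]c(=O)[nH]c3=O)nn2)c1`: 3620 nM
Compound 2 `Cc1ccc(-n2cc(-c3ccccc3NS(=O)(=O)c3c[nH]c(=O)[nH]c3=O)nn2)cc1`: 8350 nM
Compound 3 `O=c1[nH]cc(S(=O)(=O)Nc2ccccc2-c2cn(-c3ccc(F)cc3)nn2)c(=O)[nH]1`: its value is a limit of the assay, > 20000 nM

In a functional assay on HepG2 cells (Homo sapiens) for antiproliferative activity, read by MTT assay, with a stated time of 24 h (on this read-out higher numbers stand for weaker inhibition and lower numbers for stronger inhibition), compound 1 has the lowest of the two numbers given. The nearest is compound 2, with a 2.3-fold higher number from compound 1 to compound 2 (0.36 log units; beyond the scatter). The value of compound 3 is only a limit (the limit of > 20000 nM in this assay, at which 1 of the 3 values shown sits), so its step from compound 1 is known as at least modest: an at least 5.5-fold higher number from compound 1 to compound 3 (0.74 log units; beyond the scatter).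

Compound 4 `O=c1[nH]cc(S(=O)(=O)Nc2ccccc2-c2cn(-c3cccc(Cl)c3)nn2)c(=O)[nH]1` has not yet been measured. It differs from compound 1 by chloro in place of methyl on an aromatic carbon.

Going by the values given here, two measured steps bear on this change. The exchange of one group for another on the same aromatic carbon has one precedent, fluoro in place of methyl, which gave an at least 2.3-fold higher number from compound 2 to compound 3 (0.37 log units; beyond the scatter). The fuller swap of the whole aryl group gave an at least 5.5-fold higher number from compound 1 to compound 3 (0.74 log units; beyond the scatter). Both point to a weaker inhibition when methyl is replaced, though neither involves chloro and neither is fixed as an exact number.

The expectation is therefore a modest rise, a 1.9-fold higher number from compound 1 to compound 4 (0.29 log units; within the scatter), with a real chance that only a limit is reported. For compound 4 the estimate is 7000 nM, with a range from 2500 nM to 20000 nM.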

Compound 4, half-maximal inhibitory concentration: 2460 nM
The estimate for compound 4 lay 2.8-fold (0.45 log units) above the measured number, and the stated range ends above it.
By their numbers in this assay, from the lowest: compounds 4 and 1 (each within the scatter of the next); then compound 2. At a limit, above all of these: compound 3.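

In this assay, the swap from 3-methylphenyl to 3-chlorophenyl gives a 1.5-fold lower number from compound 1 to compound 4 (0.17 log units; within the scatter), so chloro and methyl cannot be told apart at this place on the ring. Going by these compounds alone, the earlier compounds showed only changes that moved the number upward, so this is the first sign that the methyl of compound 1 can be exchanged without a measurable loss. The aryl group still matters, as the other two comparisons show: a 3.4-fold lower number from compound 2 to compound 4 (0.53 log units; beyond the scatter), and an at least 8.1-fold lower number from compound 3 to compound 4 (0.91 log units; beyond the scatter). That last step has only a minimum size, since the value of compound 3 is a limit and not a number: the limit of > 20000 nM in this assay, at which 1 of the 4 values shown sits.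

Among these four compounds, the two with a 3-substituted phenyl give lower numbers than the two with a 4-substituted phenyl, with no exception, but the substituents differ and the set is small, so the role of the position alone stays open. A plain phenyl, a 3-fluorophenyl and a 4-chlorophenyl would separate position from substituent, and a methoxy group or an amine at this place would show whether groups unlike chloro and methyl fit there too.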